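A few compounds are considered here, and "the series" means these few. Any claim that something is new, unique, unknown or untested is made for them only; others in the source may bear on it.

Measured in an ADME assay on HaCaT cells (Homo sapiens) for antiproliferative activity, read by MTT assay, with a stated time of 48 h; a higher number here means a weaker inhibitor, a lower number a stronger inhibitor:
Compound 1 `O=C(/C=C\Nc1ccc(C(F)(F)F)cc1)c1cn(-c2ccccc2)nc1-c1ccccc1`: > 50000 nM, a limit of the assay.
Compound 2 `O=C(/C=C\Nc1ccc(O)cc1)c1cn(-c2ccccc2)nc1-c1ccccc1`: 44600 nM.
Compound 3 `COc1ccc(N/C=C\C(=O)c2cn(-c3ccccc3)nc2-c2ccccc2)cc1`: > 50000 nM, a limit of the assay.

Among the compounds with values here, compound 2 holds the only true number. Compounds 1 and 3 stand at the limit of > 50000 nM in this assay, at which 2 of the 3 values shown sit. Compound 4 `O=C(/C=C\Nc1ccc(O)cc1)c1cn(-c2ccccc2)nc1-c1ccc(F)cc1` carries fluoro in place of hydrogen on an aromatic carbon. Within the data shown here, no measured step makes this change. The nearest evidence is an at least 1.1-fold lower number from compound 1 to compound 2 (0.04 log units; that floor lies within the scatter) and an at least 1.1-fold higher number from compound 2 to compound 3 (0.04 log units; that floor lies within the scatter), and both steps change a different place. No step beyond the scatter is therefore expected in this assay, in either direction. The expected change is a 1.1-fold lower number from compound 2 to compound 4 (0.05 log units; within the scatter). For compound 4 the estimate is 40000 nM, with an expected range of 18000 nM to 75000 nM.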

Compound 4, half-maximal inhibitory concentration: 16300 nM
Estimate against measurement, compound 4: 2.5-fold (0.39 log units) above; measured number below the stated range.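

In this assay, within the data shown here, the change from phenyl to 4-fluorophenyl gives a 2.7-fold lower number from compound 2 to compound 4 (0.44 log units; beyond the scatter), the first step here with a full size and beyond the scatter. Among these compounds, it shows that the number responds to a change at this place, which none of the earlier steps touched. Those steps changed another place and each ran to a limit of the assay, so they gave only a floor or nothing readable: the limit of > 50000 nM in this assay, at which 2 of the 4 values shown sit.

Whether this response is particular to fluoro stays open, as the compounds shown carry no chloro, methyl or amine at this place. Also open, as far as these compounds go, is whether fluoro acts the same way alongside the trifluoromethyl of compound 1 or the methoxy of compound 3.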